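Cytotoxicity Outlook for a Naphthyl Thioether Analogue

The source may report more compounds than this note shows. Statements on the series, on what has been measured and on what is new or still open speak of the compounds shown alone.

Compound 3 `O=[N+]([O-])c1ccc(Sc2cn(-c3ccc4c(c3)B(O)OC4)c3ccccc23)cc1` is one of three thioethers on a shared core that have been examined in an ADME assay on L929 cells (Mus musculus) for cytotoxicity, read by resazurin assay, with a stated time of 72 h; on this read-out lower numbers stand for stronger inhibition and higher numbers for weaker inhibition. In this assay compound 3 gives > 10 ug/mL, which is a limit of the assay and not a number. Compound 1 `OB1OCc2ccc(-n3cc(Sc4ccc(Cl)c(Cl)c4)c4ccccc43)cc21` gives > 10 ug/mL in this assay, likewise a limit. Compound 2 `OB1OCc2ccc(-n3cc(Sc4ccc(Cl)cc4)c4ccccc43)cc21` gives > 10 ug/mL in this assay, again a limit. All three values thus sit at the limit of > 10 ug/mL in this assay, at which 3 of the 3 values shown sit, so compound 3 cannot be placed above or below its two neighbours. For the same reason the steps a step that the two limits leave unreadable from compound 1 to compound 2, a step that the two limits leave unreadable from compound 1 to compound 3 and a step that the two limits leave unreadable from compound 2 to compound 3 have no readable size.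

Compound 4 `OB1OCc2ccc(-n3cc(Sc4ccc5ccccc5c4)c4ccccc43)cc21` differs from compound 3 in one place: naphthalen-2-yl in place of 4-nitrophenyl on a sulfur. Within the data shown here, the only measured step that also exchanges the whole group on the sulfur, a step that the two limits leave unreadable from compound 1 to compound 3, gives no size to lean on, and the two single-substituent steps are equally silent. With every measured value resting at the limit, a value at or beyond that limit is expected for compound 4 as well. The step that the limit leaves unreadable from compound 3 to compound 4 is expected to be small, within the scatter. Compound 4 is therefore estimated at 15 ug/mL in this assay, in a range from 7 ug/mL to 40 ug/mL, and most probably reported only as a limit.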

Compound 4, half-maximal inhibitory concentration: > 10 ug/mL
Compound 4: only a limit was reported; the forecaster's own chance of this, stated with the estimate: 80%; the middle value does not contradict the limit.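

In this assay compound 4, like compound 1, compound 2 and compound 3, is reported only as a limit, so no step between compound 4 and any of these three can be read: the limit of > 10 ug/mL in this assay, at which 4 of the 4 values shown sit.

The compounds shown leave open whether the group on the sulfur changes the result in this assay at all, and how far apart these four compounds lie.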